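Trimethylammonium to methyl on the dihydropyridine aryl ring

The compounds below may be only part of what the source reports. "The series", "measured", "known", "first", "only" and "open" are said of these compounds alone.

Compound 1 `COC(=O)C1=C(C)N=C(C)/C(=C(\O)OC)C1c1cccc([N+](C)(C)C)c1`: 50100 nM in a functional assay (muscle tissue) with Cavia porcellus as the target; a lower number here means that less compound is needed, a higher number that more compound is needed for the effect
Compound 2 `COC(=O)C1=C(C)N=C(C)/C(=C(\O)OC)C1c1ccccc1N`: 39800 nM
Compound 3 `COC(=O)C1=C(C)N=C(C)/C(=C(\O)OC)C1c1ccccc1I`: 46.8 nM

Compound 1 gives the highest of the three numbers in this assay. Compound 2 sits within the scatter of compound 1, while compound 3 lies far below both. Among the measured compounds shown here, the one step measured, an 850-fold lower number from compound 2 to compound 3 (2.93 log units; beyond the scatter), is large and comes with the change iodo in place of amino on an aromatic carbon. Compound 4 `COC(=O)C1=C(C)N=C(C)/C(=C(\O)OC)C1c1cccc(C)c1` differs from compound 1 in this way: one carbon atom in place of a group of 4 heavy atoms (3 carbon, 1 nitrogen; no ring), on an aromatic carbon. The measured step bears on it only loosely, as a different group at a different place, but it shows that removing a nitrogen-bearing group from the aryl ring can move the number a long way down. A large step downward is therefore expected, a 170-fold lower number from compound 1 to compound 4 (2.22 log units; beyond the scatter), and compound 4 is estimated at 300 nM, between 50 nM and 2000 nM.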

Compound 4, half-maximal effective concentration: 110 nM
Compound 4: middle estimate off by 2.7-fold (0.44 log units), on the high side, and the stated range covers the measured number.
By their numbers in this assay, from the lowest: compound 3; then compound 4; then compounds 2 and 1 (each within the scatter of the next).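

On this aromatic carbon, methyl in place of the group of 4 heavy atoms with net charge +1 gives a 460-fold lower number from compound 1 to compound 4 (2.66 log units; beyond the scatter) and thus separates the high number of compound 1 from the shared core. Exchange of the whole aryl group gives a 360-fold lower number from compound 2 to compound 4 (2.56 log units; beyond the scatter) and a 2.4-fold higher number from compound 3 to compound 4 (0.37 log units; beyond the scatter) but alters both the group and its place on the ring, so these steps do not isolate either change. No measurement on hand explains any of these steps. From the compounds shown here alone, it remains open whether a carboxylic acid, a methoxy group or a longer alkyl chain at this place would give a number nearer that of compound 4 or of compound 1. Going by these compounds, how methyl compares with iodo at one and the same place also remains open.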